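The source may hold more compounds than are shown below. What is called first, only, known or untested is meant among the compounds shown, and "the series" means these compounds.

In a functional assay on NCI-H460 cells (Homo sapiens) for inhibition, read by CCK-8 assay, with a stated time of 48 h (on this read-out lower numbers stand for stronger inhibition and higher numbers for weaker inhibition), compound 1 `Cc1ccc(NC(=S)NC(=O)c2cn(-c3ccccc3)nc2-c2ccc(Cl)cc2)cc1` gives 3120 nM. Compound 2 `O=C(NC(=S)Nc1ccc(Cl)cc1)c1cn(-c2ccccc2)nc1-c1ccc(Cl)cc1` gives 3260 nM, and compound 3 `O=C(NC(=S)Nc1ccc(F)cc1)c1cn(-c2ccccc2)nc1-c1ccc(Cl)cc1` gives 3640 nM, so all three values sit within the scatter of one another, as the steps of a 1.0-fold higher number from compound 1 to compound 2 (0.02 log units; within the scatter), a 1.2-fold higher number from compound 1 to compound 3 (0.07 log units; within the scatter) and a 1.1-fold higher number from compound 2 to compound 3 (0.05 log units; within the scatter) show. Compound 4 `COc1ccc(-c2nn(-c3ccccc3)cc2C(=O)NC(=S)Nc2ccc(C)cc2)cc1` differs from compound 1 by methoxy in place of chloro on an aromatic carbon. Among the measured compounds shown here, none of the measured steps touches the 4-chlorophenyl; each swaps a group at a different place in the molecule, so no step bears directly on this change, and they show only that small swaps on an aromatic carbon left this assay unmoved. On that basis a small step is expected, a 1.1-fold higher number from compound 1 to compound 4 (0.05 log units; within the scatter). Compound 4 is therefore estimated at 3500 nM, within a range from 1500 nM to 8500 nM.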

Compound 4, half-maximal inhibitory concentration: 2880 nM
Beside the measured number, compound 4's estimate is 1.2-fold (0.08 log units) above it; low and high end bracket the measured number.
By their numbers in this assay, from the lowest: compounds 4, 1, 2 and 3 (each within the scatter of the next).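

Replacing chloro with methoxy at this position gives a 1.1-fold lower number from compound 1 to compound 4 (0.03 log units; within the scatter) in this assay. Among the compounds shown here, this is the first direct look at this place in the molecule, and the swap, which adds a hydrogen-bond acceptor and one heavy atom, leaves the number within the scatter, as the swaps made elsewhere did. Nothing measured here explains this result.

Only these two groups have been compared at this position. As far as these compounds go, whether an amine, a carboxylic acid or a longer chain there would also leave the number unmoved remains open.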